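This account rests on a few compounds, and the source may have more. Where it says the series, first, only, none or still open, it means among the compounds named here.

Three small molecules were tested in a functional assay on NCI-H522 cells (Homo sapiens) for cytotoxicity, with a stated time of 3 days; on this read-out lower numbers stand for stronger inhibition and higher numbers for weaker inhibition. Compound 1 (`C#Cc1ncccn1`) gave > 40000 nM, which is a limit of the assay and not a number. Compound 2 (`Ic1nc2ccccc2s1`) gave > 40000 nM, which is likewise only a limit. Within the data shown here, compound 3 (`C#Cc1nc(C(=O)Nc2ccc(Cl)cc2)cs1`) gave 540 nM, the only true number in the set, so it has no measured neighbour against which its potency can be gauged.

The next compound to be tested is compound 4 (`C#Cc1nc(C(=O)Nc2ccccc2)cs1`), which keeps everything in compound 3 except one substituent. The change is hydrogen in place of chloro on an aromatic carbon of a six-membered aromatic ring of carbon only, para to a large group.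

Among the measured compounds shown here, no measured pair in the set shows what such a change does in this assay, so the expectation rests on the single anchor of compound 3 at 540 nM and on the small size of the edit. A modest loss of potency seems more likely than a gain or a collapse towards the assay limit. The expected change, a 2.2-fold higher number from compound 3 to compound 4 (0.35 log units; beyond the scatter), is only slightly beyond the usual scatter. For compound 4 the estimated value is 1200 nM, with an expected range from 350 nM to 5000 nM.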

Compound 4, half-maximal inhibitory concentration: 660 nM
Estimate against measurement, compound 4: 1.8-fold (0.26 log units) above; the range from low to high includes it.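

In this assay, replacing the chloro group with hydrogen gives a 1.2-fold higher number from compound 3 to compound 4 (0.09 log units; within the scatter), so the two compounds cannot be told apart on this read-out. Among these compounds, this is the first measured comparison at this place, on an aromatic carbon of a six-membered aromatic ring of carbon only, para to a large group, and it shows that the chloro group is not needed for the activity seen in compound 3: compound 4, carrying only hydrogen there, keeps a true number rather than reaching the limit of the assay. Nothing given here bears on why the exchange of these two substituents leaves the read-out within the scatter.

The compounds shown leave open whether this tolerance extends beyond chloro and hydrogen, since a methoxy group, an amine or a carboxylic acid at the same place could read quite differently from either of them. They also leave open how much of the activity depends on the rest of the molecule, such as the amide hydrogen or the ethynyl group, and whether a single pair in one cell line says anything about other cells.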